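A few compounds are considered here, and "the series" means these few. Any claim that something is new, unique, unknown or untested is made for them only; others in the source may bear on it.

Measured in a functional assay on MIA PaCa-2 cells (Homo sapiens) for inhibition, read by MTT assay, with a stated time of 48 h, tested at 10 uM; a higher number here means more inhibition of growth at the concentration tested, a lower number less inhibition of growth:
- compound 1 `Cc1oc2c([C@H]3CCN(C)C[C@H]3O)c(O)cc(O)c2c(=O)c1C(O)c1ccc(Cl)cc1`: 15%
- compound 2 `Cc1oc2c([C@H]3CCN(C)C[C@H]3O)c(O)cc(O)c2c(=O)c1C(O)c1c(Cl)cccc1Cl`: 0%

Compound 2 stands lowest of the two at 0%. Compound 3 `Cc1oc2c([C@H]3CCN(C)C[C@H]3O)c(O)cc(O)c2c(=O)c1C(O)c1c(F)cccc1Cl` differs from it by fluoro in place of chloro on an aromatic carbon, which turns 2,6-dichlorophenyl into 2-chloro-6-fluorophenyl. Within the data shown here, only one measured step bears on this, a number 15 percentage points lower from compound 1 to compound 2 (beyond the scatter), a modest change beyond the scatter that also altered this aromatic ring. Among the measured compounds shown here, no measured pair shows this exchange directly. In this assay the expected change is small and, with compound 2 at 0%, upward if it appears at all. The expected step is a number 5 percentage points higher from compound 2 to compound 3 (within the scatter), probably within the scatter. Compound 3 is estimated at 5%, with an expected range of 0% to 15%.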

Compound 3, percent growth inhibition at one concentration: 41%
Compound 3: the middle estimate sits 36 percentage points below what was measured; measured number above the stated range.
By their numbers in this assay, from the lowest: compound 2; then compound 1; then compound 3.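

Within this assay, one exchange on an aromatic carbon ortho to a large group, fluoro in place of chloro, gives a number 41 percentage points higher from compound 2 to compound 3 (beyond the scatter), so this single position strongly affects the read-out. The ring with two substituents is therefore not poor as such, since the 2-chloro-6-fluorophenyl group gives a number 26 percentage points higher from compound 1 to compound 3 (beyond the scatter), whereas 2,6-dichlorophenyl had fallen below 4-chlorophenyl. Nothing available explains the size of this change.

Going by these compounds, it remains open whether 2,6-difluorophenyl would extend the gain. A methoxy group or an amine at this place could also behave quite differently.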